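The source may hold more compounds than are shown below. What is called first, only, known or untested is meant among the compounds shown, and "the series" means these compounds.

The measured compounds:
compound 1, `O=C(Nc1nnc(-c2cccc(O)c2O)s1)C1CCCCC1`: 19900 nM
compound 2, `CC(=O)Nc1nnc(-c2ccc(O)c(O)c2)s1`: 23400 nM

In a functional assay, with a stated time of 30 min, in the absence of a further agent (a higher number here means a weaker inhibitor, a lower number a stronger inhibitor), compound 1 gives 19900 nM and compound 2 gives 23400 nM. These two numbers lie within the usual scatter of each other, so neither compound can be set above the other; both are weak inhibitors in this assay, and compound 2 carries the higher of the two numbers only by a margin that means nothing.

Compound 3, `O=C(COc1ccccc1)Nc1nnc(-c2ccc(O)c(O)c2)s1`, has not yet been measured. It differs from compound 2 by phenoxy in place of hydrogen on a saturated chain carbon bound to a carbonyl carbon. Within the data shown here, no measured pair shows this change, so its effect cannot be read from any neighbour. Although compound 2 and compound 1 differ in more than one place, compound 1 gives 19900 nM, within the scatter of compound 2, so a large shift is not expected. The step from compound 2 to compound 3 is expected to be a 1.6-fold lower number from compound 2 to compound 3 (0.19 log units; within the scatter), a modest move toward a stronger inhibitor at most. Compound 3 is therefore estimated at 15000 nM, with a range from 5000 nM to 45000 nM.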

Compound 3, half-maximal inhibitory concentration: 36100 nM
Estimate against measurement, compound 3: 2.4-fold (0.38 log units) below; the range from low to high includes it.
By their numbers in this assay, from the lowest: compounds 1, 2 and 3 (each within the scatter of the next).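

Putting phenoxy in place of hydrogen on a saturated chain carbon bound to a carbonyl carbon gives a 1.5-fold higher number from compound 2 to compound 3 (0.19 log units; within the scatter) in this assay and so leaves the two compounds indistinguishable. This is the first step shown at this position, and it indicates that the change from methyl to phenoxymethyl, which adds a six-membered aromatic ring of carbon only, does not carry the number beyond the scatter in either direction. Nothing measured here explains this outcome.

On these data alone, it remains open whether an amine or a carboxylic acid on this same carbon, or a longer chain in place of the phenoxymethyl, would shift the number beyond the scatter. The compounds shown also leave open whether any change at this position can yield a clearly stronger inhibitor.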